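Removing the ring chloro from the decyl biguanide

This account rests on a few compounds, and the source may have more. Where it says the series, first, only, none or still open, it means among the compounds named here.

Compound 2 `CCCCCCCCCCNC(=N)NC(=N)Nc1ccc(Cl)cc1` stands highest of the three values measured in a physicochemical assay for lipophilicity, in phosphate buffer, measured as octanol-water partition, at pH 11.5; a higher number here means a more lipophilic compound, a lower number a more polar compound: compound 2 gives 6.13, compound 1 `CCCCNC(=N)NC(=N)Nc1ccc(Cl)cc1` gives 3.13, and compound 3 `CCCNC(=N)NC(=N)Nc1ccc(Cl)cc1` gives 2.63. All three measured steps concern the alkyl chain on the biguanide nitrogen: a number 3.00 log units higher from compound 1 to compound 2 (beyond the scatter), a number 3.50 log units lower from compound 2 to compound 3 (beyond the scatter) and a number 0.50 log units lower from compound 1 to compound 3 (beyond the scatter). Compound 4 `CCCCCCCCCCNC(=N)NC(=N)Nc1ccccc1` keeps the decyl chain of compound 2 and differs only on the ring: hydrogen in place of chloro on an aromatic carbon. Among the measured compounds shown here, no measured step touches the aromatic ring, so there is no step of this kind to set a size against; the chain steps only show that the series answers to a change of several carbons with a large shift in this assay and to a single carbon with a modest one. For a single heavy atom leaving the ring a step smaller than the chain steps is expected, downward, and probably just beyond the scatter: a number 0.68 log units lower from compound 2 to compound 4 (beyond the scatter) is the expected shift. Compound 4 is therefore estimated at 5.45, within the range 4.95 to 5.95.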

Compound 4, partition coefficient: 5.43
The estimate for compound 4 lay 0.02 log units above the measured number, within the range that was stated.
By their numbers in this assay, from the lowest: compound 3; then compound 1; then compound 4; then compound 2.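

In this assay, among the compounds shown here, the change from 4-chlorophenyl to phenyl gives a number 0.70 log units lower from compound 2 to compound 4 (beyond the scatter), the first measured step on the ring rather than on the chain, and it shows that this aromatic carbon, para to a large group, registers in this assay even with the decyl chain kept. The step is modest, the same printed class as the single-carbon chain step a number 0.50 log units lower from compound 1 to compound 3 (beyond the scatter), and it is a change of one heavy atom against the large steps of the chain series. Nothing at hand gives a reason for the shift.

From the compounds shown here alone, the ring change is read on the decyl chain alone, and whether it holds with the shorter chains of compound 1 and compound 3 stays open. Also open, going by these compounds, is how fluoro, methoxy or trifluoromethyl at this carbon would stand against chloro and hydrogen.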